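Swapping bromo for chloro on a shared core

The compounds below may be only part of what the source reports. "The series", "measured", "known", "first", "only" and "open" are said of these compounds alone.

Of the compounds shown here, two built on a shared core have so far been measured in an assay on HL-60 cells for inhibition of glutathione S-transferase P (Homo sapiens), read by spectrophotometry, tested at 20 uM; on this read-out higher numbers stand for more inhibition at the one concentration tested (going by the name of the read-out) and lower numbers for less inhibition. Compound 1 `Cc1ccc2c(c1)C(=O)/C(=C/c1ccc(Br)cc1)CN2CC(=O)O` gives 28.2% in this assay, the higher of the two numbers seen. Compound 2 `COc1ccc(OC)c(/C=C2\CN(CC(=O)O)c3c(C)cccc3C2=O)c1` gives 5.44% in this assay, a number that lies below that of compound 1 by more than the usual scatter of repeated measurements. For the measured compounds named here, the two differ in more than one place, so no single step between them can be read.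

Compound 3 `Cc1ccc2c(c1)C(=O)/C(=C/c1ccc(Cl)cc1)CN2CC(=O)O` has not yet been measured. It differs from compound 1 in one place only: chloro in place of bromo on an aromatic carbon. Going by the values given here, no measured pair that differs in just this way is available, so the expectation rests on compound 1 alone. The step of a number 6.2 percentage points lower from compound 1 to compound 3 (within the scatter) is expected to stay within the usual scatter, leaning if anything toward slightly less inhibition. Compound 3 is accordingly estimated to give 22% in this assay, with a range from 8% to 36%. The measured number will show whether this holds.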

Compound 3, a percentage reported as inhibition, at one concentration (the size of the read-out at that concentration, not a potency): 20.7%
Compound 3: middle estimate off by 1.3 percentage points, on the high side; the measured number falls inside the stated range.
By their numbers in this assay, from the lowest: compound 2; then compounds 3 and 1 (each within the scatter of the next).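

For the compounds shown here, the pair of compound 1 and compound 3 gives the first reading of a single change at this place, on an aromatic carbon para to a large group. In this assay the exchange of bromo for chloro comes with a number 7.5 percentage points lower from compound 1 to compound 3 (within the scatter) and so does not separate the two halogens, with 4-bromophenyl and 4-chlorophenyl reading alike on the shared core; compound 2 differs from both in more than one place, and its steps to them cannot be read. No measurement bears on why the two halogens read alike.

Going by these compounds, whether this place would keep its number with an amine or a nitrile in place of the halogen remains open, as does whether fluoro would read alike with bromo and chloro. Going by these compounds alone, also open is whether the exchange of bromo for chloro would give a comparable step on another core, for this single pair is the only reading of this change so far.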